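Swapping a furan for a bromophenol on a hydrazone arm

This account rests on a few compounds, and the source may have more. Where it says the series, first, only, none or still open, it means among the compounds named here.

Of the compounds shown here, two sharing one core have been tested in a functional assay on PC-3 cells (Homo sapiens) for antiproliferative activity, read by MTT assay; on this read-out higher numbers stand for weaker inhibition and lower numbers for stronger inhibition. Compound 1 `Cn1c(=O)c(=O)n(C2CCCC2)c2nc(N/N=C/c3ccc(S(C)(=O)=O)cc3)ncc21` carries a 4-(methylsulfonyl)phenyl group on a carbon with a double bond to nitrogen, and in this assay compound 1 gives 26600 nM. Compound 2 `Cn1c(=O)c(=O)n(C2CCCC2)c2nc(N/N=C/c3ccco3)ncc21` bears a furan-2-yl group in that place, and in this assay compound 2 gives 72200 nM. Within the data shown here, compound 2 thus stands highest of the two numbers; the only step known, a 2.7-fold higher number from compound 1 to compound 2 (0.43 log units; beyond the scatter), shows that exchanging the six-membered aromatic ring for the five-membered one weakened inhibition modestly.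

Compound 3 `Cn1c(=O)c(=O)n(C2CCCC2)c2nc(N/N=C/c3ccc(O)c(Br)c3)ncc21` is not yet measured. It differs from compound 2 as follows: 3-bromo-4-hydroxyphenyl in place of furan-2-yl on a carbon with a double bond to nitrogen. Among the measured compounds shown here, the change returns a six-membered carbon-only aromatic ring to this position, as in compound 1, so the one relevant step a 2.7-fold higher number from compound 1 to compound 2 (0.43 log units; beyond the scatter) is expected to run roughly in reverse. The step from compound 2 to compound 3 is therefore estimated as a 2.9-fold lower number from compound 2 to compound 3 (0.46 log units; beyond the scatter), toward stronger inhibition, and compound 3 is expected to give about 25000 nM, within a range of 8000 nM to 80000 nM.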

Compound 3, half-maximal inhibitory concentration: 11600 nM
The estimate for compound 3 lay 2.2-fold (0.33 log units) above the measured number; low and high end bracket the measured number.
By their numbers in this assay, from the lowest: compound 3; then compound 1; then compound 2.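

In this assay, replacing furan-2-yl with 3-bromo-4-hydroxyphenyl gives a 6.2-fold lower number from compound 2 to compound 3 (0.79 log units; beyond the scatter), a larger step than the one separating the furan from the 4-(methylsulfonyl)phenyl group, and both compounds with a six-membered aromatic ring now give lower numbers than the furan compound. Ring type is not the whole story at this position, however, since exchanging one substituted six-membered ring for the other still gives a 2.3-fold lower number from compound 1 to compound 3 (0.36 log units; beyond the scatter), showing that what the ring carries also changes the result. The data shown offer no measured explanation for why the 3-bromo-4-hydroxyphenyl group gives the lowest number of the set.

Among the compounds shown, the bromine and the hydroxyl group occur only together, so their separate contributions to the lower number of compound 3 remain unknown. As far as these compounds go, it also remains open how the number would move with an unsubstituted phenyl ring, or with an amine or a carboxylic acid on the ring at this position.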